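The source may report more compounds than this note shows. Statements on the series, on what has been measured and on what is new or still open speak of the compounds shown alone.

Measured so far:
compound 1 `Cc1c(Cc2ccccc2Br)nc(SCc2ccc([N+](=O)[O-])cc2)[nH]c1=O`; in an ADME assay on MT4 cells (Homo sapiens) for cytotoxicity, read by MTT assay (on this read-out lower numbers stand for higher toxicity in this test and higher numbers for lower toxicity in this test), compound 1 gives >= 246000 nM.
compound 2 `COc1ccc(CSc2nc(Cc3cccc(Br)c3)c(C)c(=O)[nH]2)cc1`; in this assay compound 2 gives > 290000 nM.

The value of compound 1 is a limit of the assay, not a number. The value of compound 2 is likewise a limit of the assay. Compound 2 thus stands at one of two limits, and nothing orders it against compound 1, since neither value is a number; both the limit of > 290000 nM in this assay, at which 1 of the 2 values shown sits, and the limit of >= 246000 nM in this assay, at which 1 of the 2 values shown sits, mark where the two compounds sit.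

Compound 3 `Cc1c(Cc2cccc(Br)c2)nc(SCc2ccc([N+](=O)[O-])cc2)[nH]c1=O` is not yet measured. It differs from compound 2 in one place: nitro in place of methoxy on an aromatic carbon, giving 4-nitrophenyl in place of 4-methoxyphenyl. Compound 1 also carries a 4-nitrophenyl group, and its value is a limit as well. Among the measured compounds shown here, no measured step connects the two measured compounds, so no size of step can be read off. The expectation for the step from compound 2 to compound 3 in this assay is none beyond the scatter, an at least 1.1-fold lower number from compound 2 to compound 3 (0.06 log units; that floor lies within the scatter), with the assay most probably again reporting only a limit. Compound 3 is accordingly estimated at 250000 nM, within 120000 nM to 400000 nM.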

Compound 3, half-maximal cytotoxic concentration: > 280000 nM
Compound 3 ended at the assay's limit; the forecaster's own chance of this, stated with the estimate: 80%; at least 1.1-fold (0.04 log units) between middle value and limit.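

In this assay, among the compounds shown here, compound 1, compound 2 and compound 3 all stand at limits of the assay, not at numbers, and neither the step from compound 2 to compound 3 nor the one from compound 1 to compound 3 can be read. The compounds shown leave open where their true values lie and whether nitro in place of methoxy, or 3-bromophenyl in place of 2-bromophenyl, changes this read-out at all.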